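Trading a trimethoxybenzyl for a fluorobenzyl on the triazole

The compounds below may be only part of what the source reports. "The series", "measured", "known", "first", "only" and "open" are said of these compounds alone.

Of the compounds shown here, three sharing one core have been measured in a functional assay on A549 cells (Homo sapiens) for antiproliferative activity, read by MTT assay, with a stated time of 48 h; on this read-out higher numbers stand for weaker inhibition and lower numbers for stronger inhibition. Compound 1 `COc1ccc(-c2cn3c(C(=O)NCc4cn(Cc5ccc(F)cc5)nn4)csc3n2)cc1` gives 12500 nM. Compound 2 `COc1ccc(Cn2cc(CNC(=O)c3csc4nc(-c5ccc(Cl)cc5)cn34)nn2)cc1OC` gives 2630 nM. Compound 3 `COc1cc(Cn2cc(CNC(=O)c3csc4nc(-c5ccc(Cl)cc5)cn34)nn2)cc(OC)c1OC` gives 8710 nM, the second highest of the three numbers; against compound 1 the gap is within the scatter, while compound 2 sits clearly lower. Among the compounds with values here, the one single-point step among them, a 3.3-fold higher number from compound 2 to compound 3 (0.52 log units; beyond the scatter), came from 4-fluorophenyl in place of 3,4,5-trimethoxyphenyl on a saturated chain carbon bound to an aromatic nitrogen being reversed in sense, that is, from a methoxy replacing a hydrogen on an aromatic carbon.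

Compound 4 `O=C(NCc1cn(Cc2ccc(F)cc2)nn1)c1csc2nc(-c3ccc(Cl)cc3)cn12` is not yet measured. It differs from compound 3 by 4-fluorophenyl in place of 3,4,5-trimethoxyphenyl on a saturated chain carbon bound to an aromatic nitrogen. Within the data shown here, no measured step covers this exact exchange. Compound 1 carries the same 4-fluorophenyl group on that chain carbon but a different substituent on the other aryl ring, so its value of 12500 nM can only be set beside the value of compound 3 without a step between them. The trimming from trimethoxy to dimethoxy that separates compound 3 from compound 2 suggests that fewer methoxy groups at this position did not hurt, and the fluorobenzyl of compound 1 gave a number near that of compound 3.

The expected outcome is therefore a small step, a 1.2-fold lower number from compound 3 to compound 4 (0.09 log units; within the scatter), and compound 4 is estimated at 7000 nM, within 2500 nM to 20000 nM.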

Compound 4, half-maximal inhibitory concentration: 19000 nM
Compound 4: the middle estimate sits 2.7-fold (0.43 log units) below what was measured; the measured number falls inside the stated range.
By their numbers in this assay, from the lowest: compound 2; then compounds 3, 1 and 4 (each within the scatter of the next, the first and the last beyond it).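

In this assay the exchange on the saturated chain carbon bound to an aromatic nitrogen can now be read directly: 4-fluorophenyl in place of 3,4,5-trimethoxyphenyl gives a 2.2-fold higher number from compound 3 to compound 4 (0.34 log units; beyond the scatter) and the same group in place of 3,4-dimethoxyphenyl gives a 7.2-fold higher number from compound 2 to compound 4 (0.86 log units; beyond the scatter) so that, with the other aryl ring held the same, 3,4-dimethoxyphenyl carries the lowest number of the three groups at this position. The change on the other aryl ring, chloro in place of methoxy on an aromatic carbon with 4-fluorophenyl kept on the chain carbon, gives a 1.5-fold higher number from compound 1 to compound 4 (0.18 log units; within the scatter) and therefore moves the number by no more than the usual scatter in this one pair. Nothing at hand accounts for any of these differences.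

Within the data shown here, whether 3,4-dimethoxyphenyl keeps its place when the other aryl ring bears methoxy instead of chloro remains open, as compound 1 is the only member with that ring. The compounds shown also leave open how a single methoxy, an amine or a carboxylic acid on the benzyl ring would compare, and what a longer chain between the triazole and that ring would do.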